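This account rests on a few compounds, and the source may have more. Where it says the series, first, only, none or still open, it means among the compounds named here.

Compound 1 `O=C(Nc1ccc(F)cc1)Nc1cccc(CNc2ncnc3ccccc23)c1` was examined in a functional assay on MGC-803 cells (Homo sapiens) for antiproliferative activity, read by MTT assay (a lower number here means a stronger inhibitor, a higher number a weaker inhibitor), and gave 44300 nM. Compound 2 `O=C(Nc1cccc(CNc2ncnc3ccccc23)c1)Nc1ccccc1Cl` has the change 2-chlorophenyl in place of 4-fluorophenyl on an amide-type nitrogen and, in this assay, reaches only a limit of the measurement, > 50000 nM; the step is an at least 1.1-fold higher number from compound 1 to compound 2 (0.05 log units; that floor lies within the scatter), a floor set by the limit of > 50000 nM in this assay, at which 1 of the 3 values shown sits. Compound 3 `COc1cc2ncnc(NCc3cccc(NC(=O)Nc4ccc(F)cc4)c3)c2cc1OC` gives 42100 nM in this assay; the difference between its core and that of compound 1 is not broken down here, and its value sits within the scatter of that of compound 1. Compound 4 `COc1cc2ncnc(NCc3cccc(NC(=O)Nc4ccccc4Cl)c3)c2cc1OC` carries the same change as compound 2, (2-chlorophenyl in place of 4-fluorophenyl on an amide-type nitrogen). Because compound 2 ended at the limit > 50000 nM after that change, compound 4 is expected to move by a 1.3-fold higher number from compound 3 to compound 4 (0.12 log units; within the scatter) and to end near or at the limit. The estimate for compound 4 is 55000 nM in this assay.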

Compound 4, half-maximal inhibitory concentration: 30200 nM
Beside the measured number, compound 4's estimate is 1.8-fold (0.26 log units) above it; measured number inside the range.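

In this assay, carrying the change from 4-fluorophenyl to 2-chlorophenyl onto the core of compound 3 gives a 1.4-fold lower number from compound 3 to compound 4 (0.14 log units; within the scatter), so no shift beyond the scatter appears on this core. Whether the change acts alike on the two cores is not shown: the same change on two cores in this assay, an at least 1.1-fold higher number (0.05 log units; that floor lies within the scatter) from compound 1 to compound 2 and a 1.4-fold lower number (0.14 log units; within the scatter) from compound 3 to compound 4; the limit leaves it open whether they differ Compound 2 gives only a limit of the assay, > 50000 nM.

The compounds shown leave open what a cyclohexyl group or a longer alkyl chain would give in place of these aryl groups on the amide-type nitrogen. They also leave open whether any such replacement would produce a step beyond the scatter on either core.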